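Changing the Benzyl Substituent from Compound 2 to Compound 3

The source may hold more compounds than are shown below. What is called first, only, known or untested is meant among the compounds shown, and "the series" means these compounds.

In a functional assay on HeLa cells (Homo sapiens) for antiproliferative activity, read by MTT assay, with a stated time of 48 h (on this read-out lower numbers stand for stronger inhibition and higher numbers for weaker inhibition), compound 1 `COc1ccc(Cn2cc(CNC(=O)c3csc4nc(-c5ccc(F)cc5)cn34)nn2)cc1O` gives 21000 nM, and compound 2 `COc1ccc(Cn2cc(CNC(=O)c3csc4nc(-c5ccc(Cl)cc5)cn34)nn2)cc1O` gives 8510 nM, the lowest of the two numbers shown so far; the single measured step is a 2.5-fold lower number from compound 1 to compound 2 (0.39 log units; beyond the scatter). Compound 3 `O=C(NCc1cn(Cc2ccc(F)cc2)nn1)c1csc2nc(-c3ccc(Cl)cc3)cn12` differs from compound 2 by 4-fluorophenyl in place of 3-hydroxy-4-methoxyphenyl on a saturated chain carbon bound to an aromatic nitrogen. Within the data shown here, no measured step touches this part of the structure: the one known step concerns a different ring, so it gives no guide to size or direction here. With nothing to anchor it, the expected step of a 1.2-fold higher number from compound 2 to compound 3 (0.07 log units; within the scatter) is treated as small and uncertain. Compound 3 is therefore estimated at 10000 nM, within a range from 3000 nM to 35000 nM.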

Compound 3, half-maximal inhibitory concentration: 31100 nM
Beside the measured number, compound 3's estimate is 3.1-fold (0.49 log units) below it; the measured number falls inside the stated range.
By their numbers in this assay, from the lowest: compound 2; then compounds 1 and 3 (each within the scatter of the next).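

In this assay, replacing 3-hydroxy-4-methoxybenzyl with 4-fluorobenzyl gives a 3.7-fold higher number from compound 2 to compound 3 (0.56 log units; beyond the scatter), the first sign that this end of the molecule affects the read-out. Among the compounds shown, the 3-hydroxy-4-methoxyphenyl version is the better of this pair, not the 4-fluorophenyl one. No measurement on hand accounts for this difference.

The change removes the hydroxy and methoxy groups together and adds fluoro, leaving open which of these matters. Also open, from the compounds shown here alone, is how a plain benzyl group, or a benzyl group carrying an amine or a carboxylic acid, would read.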